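A Small Change on an Amide-Type Nitrogen

The source may report more compounds than this note shows. Statements on the series, on what has been measured and on what is new or still open speak of the compounds shown alone.

In a functional assay on U-937 cells (Homo sapiens) for cytotoxicity, read by MTT assay, with a stated time of 72 h (on this read-out lower numbers stand for stronger inhibition and higher numbers for weaker inhibition), compound 1 (`Cc1c(C)c2c(c(C)c1OC(=O)CCC(=O)NC1CC(C)(C)N([O])C(C)(C)C1)CC[C@@](C)(CCC[C@H](C)CCC[C@H](C)CCCC(C)C)O2`) gives 76000 nM and compound 2 (`Cc1c(C)c2c(c(C)c1OC(=O)CCC(=O)NC1CC(C)(C)N([O])C1(C)C)CC[C@@](C)(CCC[C@H](C)CCC[C@H](C)CCCC(C)C)O2`) gives 69000 nM. Among the measured compounds shown here, compound 2 therefore stands level with the only other compound measured so far. Compound 3 (`Cc1c(C)c2c(c(C)c1OC(=O)CCC(=O)NCC1CC(C)(C)N([O])C1(C)C)CC[C@@](C)(CCC[C@H](C)CCC[C@H](C)CCCC(C)C)O2`) differs from compound 2 by a group of 11 heavy atoms (9 carbon, 1 nitrogen, 1 oxygen; one five-membered non-aromatic ring with 1 hetero atom) in place of a group of 10 heavy atoms (8 carbon, 1 nitrogen, 1 oxygen; one five-membered non-aromatic ring with 1 hetero atom), on an amide-type nitrogen, on an amide-type nitrogen. For the measured compounds named here, the one measured step that bears on this change, a 1.1-fold lower number from compound 1 to compound 2 (0.04 log units; within the scatter), also exchanged the group on that nitrogen. No step beyond the scatter is therefore expected in this assay, and the estimated step is a 1.0-fold higher number from compound 2 to compound 3 (0.01 log units; within the scatter). Compound 3 is expected at 70000 nM, within an estimated range of 35000 nM to 140000 nM.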

Compound 3, half-maximal inhibitory concentration: 137000 nM
Beside the measured number, compound 3's estimate is 2.0-fold (0.29 log units) below it, within the range that was stated.
By their numbers in this assay, from the lowest: compounds 2, 1 and 3 (each within the scatter of the next).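

Two further exchanges of the group on the amide-type nitrogen, read in this assay, also stay within the scatter (a 2.0-fold higher number from compound 2 to compound 3 (0.30 log units; within the scatter); a 1.8-fold higher number from compound 1 to compound 3 (0.26 log units; within the scatter)). Across compounds 1, 2 and 3, then, neither the five-membered ring in place of the six-membered ring nor the group of 11 heavy atoms in place of the group of 10 heavy atoms moves the number beyond the scatter.

From the compounds shown here alone, whether an amine or a carboxylic acid on this nitrogen would do so remains open. No measurement shown offers an explanation of these numbers.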